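The source may hold more compounds than are shown below. What is called first, only, known or untested is meant among the compounds shown, and "the series" means these compounds.

Measured so far:
compound 1, `CC(C)c1ccccc1NC(=O)N[C@@H](C)c1ccccc1`, 93% in an ADME assay on the whole organism with Oryza sativa as the target, tested at 10 uM; a higher number here means a weaker effect of the compound at the concentration tested, a lower number a stronger effect
compound 2, `C[C@@H](NC(=O)Nc1ccccc1Cl)c1ccccc1`, 93% in this assay

The account follows the step from compound 2 to compound 3. In this assay compound 2 gives 93%, which is level with compound 1 at the digits reported; its nearest neighbour is compound 1, and the two show no change beyond the scatter. Compound 3, `C[C@H](NC(=O)Nc1ccccc1Cl)c1ccccc1`, has not yet been measured. It differs from compound 2 in this way: the two compounds have the same atoms and bonds and differ only in configuration as drawn: 1 of 1 stereo elements differ; a stereocentre at a saturated chain carbon is drawn R in compound 2 and S in compound 3. Among the compounds with values here, no step between two measured compounds covers a change of this kind, so the size and direction of the step cannot be read from the numbers on hand. With both measured compounds standing at the same high activity in this assay, compound 3 is expected to stay within the scatter of compound 2, and the expected step is a number 3 percentage points lower from compound 2 to compound 3 (within the scatter). The estimate for compound 3 is 90%, with a range from 75% to 100%.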

Compound 3, a percentage reported as activity, at one concentration (the size of the read-out at that concentration, not a potency): 106%
Beside the measured number, compound 3's estimate is 16 percentage points below it, outside the stated range (above it).
By their numbers in this assay, from the lowest: compounds 1 and 2 (each within the scatter of the next); then compound 3.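

In this assay the configuration at the saturated chain carbon is not a silent feature: redrawing this stereocentre from R to S gives a number 13 percentage points higher from compound 2 to compound 3 (beyond the scatter). The step can be assigned to the stereocentre alone, because nothing else separates the pair: the fact that compounds 2 and 3 differ only in the configuration as drawn. Compound 3 also stands apart from compound 1, with chloro in place of isopropyl on an aromatic carbon giving a number 13 percentage points higher from compound 1 to compound 3 (beyond the scatter).

The compounds shown leave open whether the same change from R to S would give a step of similar size and direction with isopropyl in place of chloro. They also leave open how a bromo or methoxy group in place of chloro would read in this assay, and with either configuration.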